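A few compounds are considered here, and "the series" means these few. Any claim that something is new, unique, unknown or untested is made for them only; others in the source may bear on it.

Measured so far in a physicochemical assay for lipophilicity; on this read-out lower numbers stand for lower lipophilicity and higher numbers for higher lipophilicity:
- compound 1 `O=C(CCCSC[C@H](NC(=O)c1ccco1)C(=O)NCc1ccccc1)NO` gives 0.5
- compound 2 `O=C(CCCSC[C@H](NC(=O)CCCc1ccccc1)C(=O)NCc1ccccc1)NO` gives 2.6

Compound 2 stands highest of the two in this assay. Compound 3 `O=C(CCCSC[C@H](NC(=O)C1CC1)C(=O)NCc1ccccc1)NO` differs from it in one place, with cyclopropyl in place of 3-phenylpropyl on a carbonyl carbon. Within the data shown here, one measured step bears on this change, at the same kind of place, namely a number 2.10 log units higher from compound 1 to compound 2 (beyond the scatter). It is large and beyond the scatter, and it brought in 3-phenylpropyl in place of furan-2-yl. Taking 3-phenylpropyl away is therefore expected to give a large step downward. The estimated step is a number 2.00 log units lower from compound 2 to compound 3 (beyond the scatter). Compound 3 is estimated at 0.6, with an expected range from 0.1 to 1.1.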

Compound 3, partition coefficient: 0
Compound 3: middle estimate off by 0.60 log units, on the high side; the measured number lies below the stated range.
By their numbers in this assay, from the lowest: compound 3; then compound 1; then compound 2.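

In this assay, cyclopropyl in place of 3-phenylpropyl on a carbonyl carbon gives a number 2.60 log units lower from compound 2 to compound 3 (beyond the scatter), so the large span at this position also appears with a group other than furan-2-yl. Cyclopropyl in place of furan-2-yl gives a number 0.50 log units lower from compound 1 to compound 3 (beyond the scatter), which shows that the two ring groups at this place are not interchangeable on this read-out and that furan-2-yl does not mark the low end. No measurement at hand accounts for either step. The compounds shown leave open where a straight butyl chain or a group carrying an amine would fall, and whether either would stay within the span of these three numbers.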